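Pyridin-4-yl Variant at the Ethenyl Terminus

A few compounds are considered here, and "the series" means these few. Any claim that something is new, unique, unknown or untested is made for them only; others in the source may bear on it.

Among the measured compounds shown here, compound 3 `COc1ccccc1/C=C/C[C@H]1C[C@@H]([C@@H](O)c2ccccc2)CO[C@@H]1c1ccccc1` gives 14700 nM in a functional assay on HeLa cells (Homo sapiens) for cytotoxicity, read by WST assay, with a stated time of 48 h (on this read-out higher numbers stand for weaker inhibition and lower numbers for stronger inhibition), the second highest of the three numbers so far. Compound 2 `COc1ccc(/C=C/C[C@H]2C[C@@H]([C@@H](O)c3ccccc3)CO[C@@H]2c2ccccc2)cc1` sits nearest with 8300 nM, and compound 1 `O[C@@H](c1ccccc1)[C@H]1CO[C@H](c2ccccc2)[C@@H](C/C=C/c2ccccn2)C1` furthest with 33800 nM. The step of a 1.8-fold higher number from compound 2 to compound 3 (0.25 log units; within the scatter) lies within the scatter, whereas a 2.3-fold lower number from compound 1 to compound 3 (0.36 log units; beyond the scatter) and a 4.1-fold lower number from compound 1 to compound 2 (0.61 log units; beyond the scatter) lie beyond it, so the pyridin-2-yl compound stands apart from both methoxyphenyl compounds.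

Compound 4 `O[C@@H](c1ccccc1)[C@H]1CO[C@H](c2ccccc2)[C@@H](C/C=C/c2ccncc2)C1` differs from compound 3 as follows: pyridin-4-yl in place of 2-methoxyphenyl on a double-bonded chain carbon bound to a double-bonded chain carbon. For the measured compounds named here, the only measured step bearing on this is a 2.3-fold lower number from compound 1 to compound 3 (0.36 log units; beyond the scatter), which read in reverse means that exchanging 2-methoxyphenyl for pyridin-2-yl gave a modest rise. Going by the values given here, no measured step covers pyridin-4-yl, and its size relative to pyridin-2-yl is unknown, so the reverse of that step is taken as the best guide. A modest rise in this assay is therefore expected, a 1.9-fold higher number from compound 3 to compound 4 (0.28 log units; within the scatter). Compound 4 is estimated at 28000 nM. The expected range for compound 4 runs from 12000 nM to 70000 nM.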

Compound 4, half-maximal inhibitory concentration: > 100000 nM
Compound 4 ended at the assay's limit; the forecaster's own chance of this, stated with the estimate: 10%; at least 3.5-fold (0.55 log units) between middle value and limit.
By their numbers in this assay, from the lowest: compounds 2 and 3 (each within the scatter of the next); then compound 1. At a limit, above all of these: compound 4.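

In this assay compound 4 gives > 100000 nM, which is a limit of the assay and not a number: the limit of > 100000 nM in this assay, at which 1 of the 4 values shown sits.

Among the compounds shown here, the position on the double-bonded chain carbon distinguishes two pyridine isomers, with pyridin-4-yl in place of pyridin-2-yl giving an at least 2.9-fold higher number from compound 1 to compound 4 (0.47 log units; beyond the scatter), whereas the earlier compounds held only one pyridine. Against the methoxyphenyl compounds, the change gives an at least 6.8-fold higher number from compound 3 to compound 4 (0.83 log units; beyond the scatter) and an at least 12-fold higher number from compound 2 to compound 4 (1.08 log units; beyond the scatter), both wider than any step among compound 1, compound 2 and compound 3.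

As far as these compounds go, the true sizes of these steps remain open, as does how far compound 4 lies past the limit. Also open, from the compounds shown here alone, is how pyridin-3-yl, unsubstituted phenyl or a phenyl carrying an aminomethyl group would read at this position.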